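This account rests on a few compounds, and the source may have more. Where it says the series, first, only, none or still open, it means among the compounds named here.

Compounds measured in an ADME assay on HEK293 cells (Homo sapiens) for cytotoxicity, read by CCK-8 assay and cell counting, with a stated time of 2 days; on this read-out lower numbers stand for stronger inhibition and higher numbers for weaker inhibition:
- compound 1, `Oc1cccc(-c2cc(-c3ccc(Cl)cc3)nc(-c3cccs3)c2)c1`, 11800 nM
- compound 2, `Oc1ccc(-c2cc(-c3ccc(Cl)cc3)nc(-c3cccs3)c2)cc1`, 4520 nM
- compound 3, `Oc1ccc(-c2cc(-c3cccc(Cl)c3)nc(-c3cccs3)c2)cc1`, 2720 nM

Compound 2 stands second highest of the three numbers in this assay: its nearest neighbour is compound 3, which gives 2720 nM, and the step of a 1.7-fold lower number from compound 2 to compound 3 (0.22 log units; within the scatter) is within the scatter; the furthest is compound 1, which gives 11800 nM, and the step of a 2.6-fold lower number from compound 1 to compound 2 (0.42 log units; beyond the scatter) lies beyond the scatter.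

Compound 4, `Oc1ccc(-c2cc(-c3ccccc3)nc(-c3ccc(Cl)cc3)c2)cc1`, has not been measured. It differs from compound 2 by phenyl in place of thiophen-2-yl on an aromatic carbon. Neither measured step touches the thiophen-2-yl group: the step from compound 1 to compound 2 changes the hydroxyphenyl, the step from compound 2 to compound 3 changes the chlorophenyl. The change from compound 2 to compound 4 therefore has no measured counterpart among these compounds, and the two measured steps were modest or within the scatter. No step beyond the scatter is expected from compound 2 to compound 4 in this assay; the expected step is a 1.0-fold lower number from compound 2 to compound 4 (0.00 log units; within the scatter). For compound 4 the estimate in this assay is 4500 nM, with a range from 1500 nM to 14000 nM.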

Compound 4, half-maximal inhibitory concentration: 4810 nM
Compound 4: the middle estimate sits 1.1-fold (0.03 log units) below what was measured, within the range that was stated.
By their numbers in this assay, from the lowest: compounds 3, 2 and 4 (each within the scatter of the next); then compound 1.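

Among these compounds, the group on the aromatic carbon next to the ring nitrogen stayed the same in the earlier compounds; in this assay, phenyl in place of thiophen-2-yl gives a 1.1-fold higher number from compound 2 to compound 4 (0.03 log units; within the scatter). In this one pair, the read-out does not separate a five-membered aromatic ring with a hetero atom from a six-membered aromatic ring of carbon only, so the sulfur atom is not required for a number of this size. Nothing available explains why the two groups read alike.

As far as these compounds go, it remains open whether a group of another kind at this position, such as an amine, a carboxylic acid or a longer alkyl chain, would move the number beyond the scatter. From the compounds shown here alone, it is also open whether the same exchange would read alike on the core of compound 1 or compound 3.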